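Swapping the Aryl Group and Watching Cell Toxicity

This account rests on a few compounds, and the source may have more. Where it says the series, first, only, none or still open, it means among the compounds named here.

Within the data shown here, compound 1 `COc1cccc(-c2cc(C)c3ncc(CSCCc4ccccc4)n3c2)c1` is the only member of this set with a plain number in an ADME assay on HEL cells (Homo sapiens) for cytotoxicity, with a stated time of 3 days (on this read-out higher numbers stand for lower toxicity in this test and lower numbers for higher toxicity in this test), where compound 1 gives 36 ug/mL. Compound 2 `Cc1cc(-c2ccsc2)c2ncc(CSCCc3ccccc3)n2c1` gives > 50 ug/mL in this assay, which is a limit of the test and not a number. Compound 3 `Cc1cc(I)c2ncc(CSCCc3ccccc3)n2c1` likewise gives > 50 ug/mL, again a limit. Among the measured compounds shown here, the step from compound 2 to compound 3 a step that the two limits leave unreadable from compound 2 to compound 3 therefore cannot be sized, and no other measured step bears on the change to compound 4 `Cc1cc(-c2ccccc2O)cn2c(CSCCc3ccccc3)cnc12`, which is 2-hydroxyphenyl in place of 3-methoxyphenyl on an aromatic carbon. For the measured compounds named here, with the limit of > 50 ug/mL in this assay, at which 2 of the 3 values shown sit, as the only guide, a move toward that limit seems about as likely as no change beyond the scatter, so no direction is firmly expected. Compound 4 is estimated at 45 ug/mL, between 20 ug/mL and 100 ug/mL, an expected step of a 1.3-fold higher number from compound 1 to compound 4 (0.10 log units; within the scatter).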

Compound 4, half-maximal cytotoxic concentration: > 50 ug/mL
Compound 4: no number, only a limit; the forecaster's own chance of this, stated with the estimate: 50%; middle value at least 1.1-fold (0.04 log units) away from the limit.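

In this assay, 2-hydroxyphenyl in place of 3-methoxyphenyl gives an at least 1.3-fold higher number from compound 1 to compound 4 (0.14 log units; that floor lies within the scatter), so this aromatic carbon can carry an aryl group with a hydrogen-bond donor without the number falling. From the compounds shown here alone, compound 4 gives a limit and not a number, so the full size of the step stays unknown. The read-out now has little room left to separate compounds: the limit of > 50 ug/mL in this assay, at which 3 of the 4 values shown sit.

The compounds shown do not separate the change from methoxy to hydroxy from the shift of that group around the ring. They also leave open how a 3-hydroxyphenyl or an aminophenyl group would read here.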